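The compounds below may be only part of what the source reports. "The series", "measured", "known", "first", "only" and "open" are said of these compounds alone.

Compound 1 `CNC(=O)c1cc(C(=O)NC2CC2)cn(Cc2cccc(OC)c2)c1=O`: 582 ug/mL
Compound 2 `CNC(=O)c1cc(C(=O)NC2CCC2)cn(Cc2ccccn2)c1=O`: 920 ug/mL
Compound 3 `CNC(=O)c1cc(C(=O)NC2CCC2)cn(Cc2cccnc2)c1=O`: 189 ug/mL

In a physicochemical assay for solubility, read by HPLC, in simulated intestinal fluid, with a stated time of 16 h, tested at 125 ug/mL (on this read-out higher numbers stand for higher solubility and lower numbers for lower solubility), compound 1 gives 582 ug/mL, the second highest of the three numbers; compound 2 lies within the scatter of it, while compound 3 gives a lower number by more than the scatter. Compound 4 `CNC(=O)c1cc(C(=O)NC2CC2)cn(Cc2cccc([C@@H](C)O)c2)c1=O` is compound 1 with a single change: 1-hydroxyethyl in place of methoxy on an aromatic carbon. Within the data shown here, the only measured step, a 4.9-fold lower number from compound 2 to compound 3 (0.69 log units; beyond the scatter), exchanges one pyridinyl for another on the saturated chain carbon bound to the aromatic nitrogen, a different part of the shared core, so no measured step bears on the present change. For compound 4 the expectation is therefore no step beyond the scatter, with the number estimated at 650 ug/mL, between 300 ug/mL and 1200 ug/mL, which means a 1.1-fold higher number from compound 1 to compound 4 (0.05 log units; within the scatter).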

Compound 4, solubility: 495 ug/mL
Compound 4: middle estimate off by 1.3-fold (0.12 log units), on the high side; the measured number falls inside the stated range.
By their numbers in this assay, from the lowest: compound 3; then compounds 4, 1 and 2 (each within the scatter of the next).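

In this assay putting 1-hydroxyethyl in place of methoxy on an aromatic carbon gives a 1.2-fold lower number from compound 1 to compound 4 (0.07 log units; within the scatter) and so, at this position, a hydrogen-bond donor and a defined stereocentre enter without a step beyond the scatter. Among these compounds, this is the first measured step at this place on the shared core, since the earlier step exchanged pyridinyl groups elsewhere. Nothing available explains the result. Still open, from the compounds shown here alone, is whether the opposite stereoisomer of 1-hydroxyethyl reads alike, and whether an amine or a carboxylic acid here would shift the number beyond the scatter.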